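The source may hold more compounds than are shown below. What is called first, only, known or untested is meant among the compounds shown, and "the series" means these compounds.

Compound 1 `CCCCOc1ncc(-c2ccccc2OC)n1C`: 87000 nM
Compound 2 `COc1ccccc1-c1cnc(OC)n1C`: > 100000 nM, a limit of the assay
Compound 3 `C=CCCCCOc1ncc(-c2ccccc2OC)n1C`: 5000 nM

All three compounds were tested in a functional assay on A549 cells (Homo sapiens) for inhibition, read by colorimetric assay and MTT assay, with a stated time of 72 h; on this read-out higher numbers stand for weaker inhibition and lower numbers for stronger inhibition. Only two of the results are actual numbers, and compound 3 holds the lower of them, with a 17-fold lower number from compound 1 to compound 3 (1.24 log units; beyond the scatter). The result for compound 2 is a limit, so the steps that involve it are bounds: an at least 1.1-fold higher number from compound 1 to compound 2 (0.06 log units; that floor lies within the scatter), and an at least 20-fold lower number from compound 2 to compound 3 (1.30 log units; beyond the scatter).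

The next compound is compound 4 `COc1ccccc1-c1cnc(OCCCc2ccccc2)n1C`. The change is phenyl in place of allyl on a saturated chain carbon, three bonds along the chain from an oxygen on an aromatic ring. Within the data shown here, no measured compound carries a ring on this chain, so no step tests the swap directly. The nearest guide is a 17-fold lower number from compound 1 to compound 3 (1.24 log units; beyond the scatter), a large step made by extending the far end of the chain. Compound 4 keeps a group at that far end, so it is expected to stay close to compound 3 rather than fall back towards compound 1. No step beyond the scatter is therefore expected in this assay, and the estimate is a 1.2-fold higher number from compound 3 to compound 4 (0.08 log units; within the scatter). The estimated value for compound 4 is 6000 nM, with an expected range of 1500 nM to 30000 nM.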

Compound 4, half-maximal inhibitory concentration: 3000 nM
For compound 4 the middle estimate is 2.0-fold (0.30 log units) above the measured one; the measured number falls inside the stated range.
By their numbers in this assay, from the lowest: compounds 4 and 3 (each within the scatter of the next); then compound 1. At a limit, above all of these: compound 2.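

In this assay, an aromatic ring at the far end of the chain does no worse than a terminal double bond: phenyl in place of allyl, on a saturated chain carbon three bonds along the chain from an oxygen on an aromatic ring, gives a 1.7-fold lower number from compound 3 to compound 4 (0.22 log units; within the scatter), so the two end groups cannot be told apart here. Measured against the saturated chain, the same place carries a large change, with phenyl in place of methyl giving a 29-fold lower number from compound 1 to compound 4 (1.46 log units; beyond the scatter), so among these compounds the large step seen with compound 3 does not depend on a double bond. The result for compound 2 is a limit of the assay, which makes an at least 33-fold lower number from compound 2 to compound 4 (1.52 log units; beyond the scatter) a bound rather than a measured size, and compound 2 is the only one of the compounds at that limit: the limit of > 100000 nM in this assay, at which 1 of the 4 values shown sits.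

The compounds shown leave open whether a longer saturated chain with neither ring nor double bond would match compound 3 and compound 4. They also leave open how a chain ending in an amine, a carboxylic acid or a fluorophenyl group would read in this assay.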